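The compounds below may be only part of what the source reports. "The series", "measured", "known", "first", "only" and "open" are said of these compounds alone.

Going by the values given here, compound 1 `Cc1cc(S(=O)(=O)/N=C(\N)n2nccc2-c2ccccc2)c(SCc2cccc(Cl)c2)cc1Cl` gives 10000 nM in a functional assay on HeLa cells (Homo sapiens) for cytotoxicity, read by MTT assay, with a stated time of 72 h (on this read-out higher numbers stand for weaker inhibition and lower numbers for stronger inhibition), the highest of the two numbers so far. Compound 2 `Cc1cc(S(=O)(=O)/N=C(\N)n2nccc2-c2ccccc2)c(SCc2ccccc2)cc1Cl` gives 5000 nM in this assay; the step of a 2.0-fold lower number from compound 1 to compound 2 (0.30 log units; within the scatter) replaces a chloro with hydrogen on an aromatic carbon and stays within the scatter. Compound 3 `Cc1cc(-c2ccccc2)n(/C(N)=N/S(=O)(=O)c2cc(C)c(Cl)cc2SCc2cccc(Cl)c2)n1` differs from compound 1 by methyl in place of hydrogen on an aromatic carbon, a methyl on the five-membered aromatic ring with 2 nitrogen. Among the compounds with values here, no measured step touches that ring, and nothing in the two numbers points to a shift beyond the scatter. The step of no change at the digits printed from compound 1 to compound 3 (within the scatter) is expected to be flat. Compound 3 is estimated at 10000 nM, with a range of 4000 nM to 25000 nM.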

Compound 3, half-maximal inhibitory concentration: 8000 nM
For compound 3 the middle estimate is 1.3-fold (0.10 log units) above the measured one, and the stated range covers the measured number.
By their numbers in this assay, from the lowest: compounds 2, 3 and 1 (each within the scatter of the next).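

Methyl in place of hydrogen on an aromatic carbon of the five-membered aromatic ring with 2 nitrogen gives a 1.3-fold lower number from compound 1 to compound 3 (0.10 log units; within the scatter) in this assay. This ring, untouched by the earlier step, therefore takes this single added carbon without a shift beyond the scatter. No evidence on the result is available to explain this reading.

Going by these compounds, whether an ethyl, an amine or a carboxylic acid on the same carbon would also stay within the scatter remains open. On these data alone, whether methyl there reads the same without the chloro on the benzyl group is also open.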